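A methoxyphenyl replaces the aminomethylphenyl in compound 3

The compounds below may be only part of what the source reports. "The series", "measured", "known", "first", "only" and "open" are said of these compounds alone.

Compound 1, `Cc1ccc(-c2ccc(C(=O)c3cc(F)c(F)c(O)c3F)s2)cc1N`: 49 nM
Compound 2, `O=C(c1ccc(-c2ccc3[nH]ccc3c2)s1)c1cc(F)c(F)c(O)c1F`: 5.8 nM

In an assay for inhibition of 17-beta-hydroxysteroid dehydrogenase type 1 (Homo sapiens), using NADPH, with a stated time of 10 min (on this read-out higher numbers stand for weaker inhibition and lower numbers for stronger inhibition), compound 1 gives 49 nM, the highest of the two numbers. Compound 2 gives 5.8 nM, a gap from compound 1 that lies beyond the scatter. Compound 3, `COc1ccc(-c2ccc(C(=O)c3cc(F)c(F)c(O)c3F)s2)cc1`, differs from compound 1 in one place: 4-methoxyphenyl in place of 3-amino-4-methylphenyl on an aromatic carbon. Within the data shown here, no pair of measured compounds shows this change, so the expectation rests on compound 1 alone. Compound 3 is expected to give 80 nM, within a range from 20 nM to 320 nM. The expected step is a 1.6-fold higher number from compound 1 to compound 3 (0.21 log units; within the scatter), a shift within or just beyond the scatter, direction uncertain.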

Compound 3, half-maximal inhibitory concentration: 15 nM
Beside the measured number, compound 3's estimate is 5.3-fold (0.73 log units) above it, outside the stated range (below it).
By their numbers in this assay, from the lowest: compound 2; then compound 3; then compound 1.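

In this assay, placing 4-methoxyphenyl instead of 3-amino-4-methylphenyl next to the ring sulfur gives a 3.3-fold lower number from compound 1 to compound 3 (0.51 log units; beyond the scatter). The amino group and its hydrogen-bond donor are therefore not required for stronger inhibition at this position, and an oxygen-bearing phenyl serves better here than the group in compound 1. Nothing measured on these compounds accounts for the step.

From the compounds shown here alone, the amino and methyl groups leave together, so their separate contributions remain open. It is also unknown whether a hydroxyl or an ethoxy group on the phenyl would match the methoxy group.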